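Chloro for Fluoro on a Shared Aryl Ring

The compounds below may be only part of what the source reports. "The series", "measured", "known", "first", "only" and "open" are said of these compounds alone.

The three compounds measured so far, each with its result in a functional assay on the whole organism (strain Albino) with Mus musculus as the target, with a stated time of 4 h; a higher number here means that more compound is needed for the effect, a lower number that less compound is needed:
Compound 1 `COc1ccc(-c2cc(-c3ccc(F)cc3)nc(NC(=O)N/N=C\c3ccc([N+](=O)[O-])cc3)n2)cc1OC` gives 300 mg/kg.
Compound 2 `C/C(=N/NC(=O)Nc1nc(-c2ccc(C)cc2)cc(-c2ccc(F)cc2)n1)c1ccc([N+](=O)[O-])cc1` gives 300 mg/kg.
Compound 3 `COc1ccc(-c2cc(-c3ccc(Cl)cc3)nc(NC(=O)N/N=C\c3ccc([N+](=O)[O-])cc3)n2)cc1OC` gives 100 mg/kg.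

Compound 1 and compound 3 share a core and differ in one place: chloro in place of fluoro on an aromatic carbon. That single change produced a 3.0-fold lower number from compound 1 to compound 3 (0.48 log units; beyond the scatter). Compound 2 rests on a different core; the difference between the two cores is not broken down here. In this assay compound 2 stands level with compound 1, within the usual scatter, so no order between those two can be read.

Compound 4 `C/C(=N/NC(=O)Nc1nc(-c2ccc(C)cc2)cc(-c2ccc(Cl)cc2)n1)c1ccc([N+](=O)[O-])cc1`, not yet measured, is to compound 2 what compound 3 is to compound 1: the same change, (chloro in place of fluoro on an aromatic carbon), made at the same place. On the strength of that one precedent, the step from compound 2 to compound 4 is expected to be about as large, a 3.0-fold lower number from compound 2 to compound 4 (0.48 log units; beyond the scatter), because the matching change gave a 3.0-fold lower number from compound 1 to compound 3 (0.48 log units; beyond the scatter). Compound 4 is therefore estimated at 100 mg/kg, with a likely range of 50 mg/kg to 250 mg/kg, resting on a single pair of compounds.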

Compound 4, dose for half-maximal effect: 300 mg/kg
Compound 4: middle estimate off by 3.0-fold (0.48 log units), on the low side; the measured number lies above the stated range.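

In this assay, going from 4-fluorophenyl to 4-chlorophenyl gives no change at the digits printed from compound 2 to compound 4 (within the scatter). Set beside the earlier step, this shows that the same swap does not behave alike on the two cores: the same change on two cores in this assay, a 3.0-fold lower number (0.48 log units; beyond the scatter) from compound 1 to compound 3 and no change at the digits printed (within the scatter) from compound 2 to compound 4, 3.0-fold (0.48 log units) apart, beyond the scatter of two such steps. It follows that the drop seen on the core of compound 1 cannot be assumed to carry over to another core in this series, but with a single pair on each core, it does not show which difference between the cores is responsible or why the result changes.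

The compounds shown leave open whether the swap has an effect on a third core, and whether changing only one part of a core at a time would restore the step seen on the core of compound 1. They also leave open how a different group at this place, such as bromo, methoxy or an amine, would fare on either core.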